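The source may hold more compounds than are shown below. What is called first, only, known or untested is meant among the compounds shown, and "the series" means these compounds.

Measured compounds in a functional assay on the whole organism for inhibition, with Rattus norvegicus as the target, at a dose of 30 mg/kg; on this read-out lower numbers stand for less inhibition and higher numbers for more inhibition at the one dose given (going by the name of the read-out):

compound 1 `CN(C)C(=S)n1ncnc1N`, for which compound 1 gives 34%
compound 2 `C/N=C(\S)c1[nH]cnc1N`, for which compound 2 gives 5%
compound 3 `C/N=C(\S)n1nc(-c2ccccc2)nc1N`, for which compound 3 gives 54%

Among these three numbers compound 3 stands highest. Its nearest neighbour is compound 1, whose number in this assay lies lower by a gap beyond the usual scatter; the furthest is compound 2, whose number lies lower still, also by a gap beyond the scatter. For the measured compounds named here, no pair of these measured compounds differs in one place only, so no step between them can be read off directly, and the three values are taken as they stand.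

The next compound, compound 4 `C/N=C(\S)n1nc(-c2ccc(C)cc2)nc1N`, differs from compound 3 by methyl in place of hydrogen on an aromatic carbon. Going by the values given here, no measured pair shows what such a change does in this assay, so the expectation rests on compound 3 alone. Because compound 3 gives 54%, compound 4 is expected to land close to it, with no step beyond the scatter in either direction. The step of a number 1 percentage points higher from compound 3 to compound 4 (within the scatter) is the one this estimate means and is expected to stay within the scatter. Compound 4 is therefore estimated at 55%, with a range from 35% to 75%.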

Compound 4, a percentage reported as inhibition, in the whole organism at one dose (the size of the read-out at that dose, not a potency): 65%
For compound 4 the middle estimate is 10 percentage points below the measured one, and the stated range covers the measured number.
By their numbers in this assay, from the lowest: compound 2; then compound 1; then compound 3; then compound 4.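

In this assay, methyl in place of hydrogen on an aromatic carbon, para to a large group, gives a number 11 percentage points higher from compound 3 to compound 4 (beyond the scatter) and so lies beyond the usual scatter. For the compounds shown here, this is the only step in the set that can be read at a single place, as none of the earlier compounds differed from one another in one place only. It shows that this position on the six-membered aromatic ring of carbon only accepts a methyl with a modest rise in inhibition at the one dose given, rather than a loss. Nothing measured here bears on why the number rises, so the rise stays an observation tied to this one pair.

As far as these compounds go, what stays open is whether the rise belongs to methyl alone or would also follow from another group at this place, such as a methoxy group, a chlorine atom, an amine or a longer chain like ethyl. From the compounds shown here alone, it is equally open whether a methyl elsewhere on that ring would move the number at all, and whether the same step would hold on a different core, such as that of compound 1.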